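Extending the amide chain of compound 1 with a methylpiperazine

The source may hold more compounds than are shown below. What is called first, only, known or untested is meant among the compounds shown, and "the series" means these compounds.

In a functional assay on MCF7 cells (Homo sapiens) for antiproliferative activity, read by MTT assay, with a stated time of 72 h (on this read-out lower numbers stand for stronger inhibition and higher numbers for weaker inhibition), compound 1 `CC/C=C/C(=O)Nc1cc2c(N3CCc4ccccc43)ncnc2cc1OC` gives 4030 nM, the lowest of the three numbers measured. Its nearest neighbour is compound 3 `CC/C=C/C(=O)Nc1cc2c(N3CCc4ccccc43)ncnc2cc1O[C@@H]1CCOC1`, which in this assay gives 8840 nM; the step from compound 1 to compound 3 is a 2.2-fold higher number from compound 1 to compound 3 (0.34 log units; beyond the scatter), with oxolan-3-yl in place of methyl on an oxygen on an aromatic ring. Furthest away is compound 2 `C=C(C)C(=O)Nc1cc2c(N3CCc4ccccc43)ncnc2cc1O[C@@H]1CCOC1`, which in this assay gives 14700 nM. The step from compound 2 to compound 3 is a 1.7-fold lower number from compound 2 to compound 3 (0.22 log units; within the scatter), for but-1-en-1-yl in place of 1-methylethenyl on a carbonyl carbon.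

Compound 4 `COc1cc2ncnc(N3CCc4ccccc43)c2cc1NC(=O)/C=C/CN1CCN(C)CC1` keeps the methyl on the ring oxygen of compound 1 and changes only the amide chain: 4-methylpiperazin-1-yl in place of methyl on a saturated chain carbon bound to a double-bonded chain carbon. Neither measured step touches this position. The step from compound 1 to compound 3 concerns the ring oxygen, and the step from compound 2 to compound 3 concerns the chain next to the carbonyl, so both are at best indirect guides, and the one direct change at the chain end has no precedent among these compounds. With so little to go on, compound 4 is expected to lie close to compound 1, as a 1.2-fold lower number from compound 1 to compound 4 (0.06 log units; within the scatter), with a wide margin either way. Compound 4 is therefore estimated at 3500 nM in this assay, with a range from 800 nM to 15000 nM.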

Compound 4, half-maximal inhibitory concentration: 6430 nM
For compound 4 the middle estimate is 1.8-fold (0.26 log units) below the measured one; measured number inside the range.
By their numbers in this assay, from the lowest: compounds 1, 4, 3 and 2 (each within the scatter of the next, the first and the last beyond it).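

In this assay, putting 4-methylpiperazin-1-yl in place of methyl on a saturated chain carbon bound to a double-bonded chain carbon gives a 1.6-fold higher number from compound 1 to compound 4 (0.20 log units; within the scatter), so this read-out does not separate the two compounds. The earlier steps shown here concerned other parts of the molecule, and this one shows that the chain end accepts a far larger group, with one six-membered non-aromatic ring and 2 hydrogen-bond acceptors, without a change beyond the scatter, though the new group brings no gain over methyl either. Nothing measured here bears on why the larger group leaves the number within the scatter.

The compounds shown leave open whether another amine at this chain end, such as dimethylamino or morpholin-4-yl, or a longer chain carrying the 4-methylpiperazin-1-yl group, would give a clearly different number. They also leave open whether 4-methylpiperazin-1-yl would have the same small effect on the amide chain of compound 3, which carries oxolan-3-yl in place of methyl on the ring oxygen.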